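The source may hold more compounds than are shown below. What is called first, only, known or untested is meant among the compounds shown, and "the series" means these compounds.

In a functional assay on MGC-803 cells (Homo sapiens) for inhibition, read by MTT assay, with a stated time of 72 h (on this read-out lower numbers stand for stronger inhibition and higher numbers for weaker inhibition), three compounds of the shared core have been run. Compound 1 `C#CCSc1nc(Nc2cccc(C(F)(F)F)c2)c(C#N)c(-c2ccccc2)n1` reaches only a limit of the assay, > 128000 nM, the point named by the limit of > 128000 nM in this assay, at which 1 of the 3 values shown sits. Compound 2 `C#CCSc1nc(Nc2ccccc2Cl)c(C#N)c(-c2ccccc2)n1` gives 52800 nM in this assay. Compound 3 `N#Cc1c(Nc2cccc(C(F)(F)F)c2)nc(SCc2cn(Cc3ccccc3Cl)nn2)nc1-c1ccccc1` gives 22800 nM in this assay, the lower of the two numbers, and its gap to compound 2 lies beyond the usual scatter. Compound 4 `COc1ccccc1Nc1nc(SCc2cn(Cc3ccccc3Cl)nn2)nc(-c2ccccc2)c1C#N` has not yet been measured; it differs from compound 3 by 2-methoxyphenyl in place of 3-(trifluoromethyl)phenyl on a nitrogen on an aromatic ring. The expected step in this assay is a 1.5-fold lower number from compound 3 to compound 4 (0.18 log units; within the scatter), a modest move that may stay within the scatter. Compound 4 is thus estimated at 15000 nM in this assay, within a range from 4000 nM to 60000 nM.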

Compound 4, half-maximal inhibitory concentration: 5800 nM
Beside the measured number, compound 4's estimate is 2.6-fold (0.41 log units) above it, within the range that was stated.
By their numbers in this assay, from the lowest: compound 4; then compound 3; then compound 2. At a limit, above all of these: compound 1.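

In this assay, going by these compounds alone, replacing 3-(trifluoromethyl)phenyl with 2-methoxyphenyl on the nitrogen gives a 3.9-fold lower number from compound 3 to compound 4 (0.59 log units; beyond the scatter), the first step whose size can be read. It shows that, with the rest of the shared core unchanged, the group on this nitrogen can by itself move the number beyond the scatter. Nothing measured here accounts for this step. 

From the compounds shown here alone, it remains open whether the step comes from gaining the methoxy group or from losing the trifluoromethyl group. Going by these compounds, how a plain phenyl or a cyclohexyl on this nitrogen would compare also remains open.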